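This account rests on a few compounds, and the source may have more. Where it says the series, first, only, none or still open, it means among the compounds named here.

Compound 1, `Cc1cc(Nc2cc(N3CCN(C)CC3)nc(Nc3cccc(Cl)c3)n2)n[nH]1`: 97.2 nM; compound 2, `Cc1cc(Nc2cc(N3CCN(C)CC3)nc(Nc3ccc(Cl)cc3)n2)n[nH]1`: 192 nM; compound 3, `Cc1cc(Nc2cc(N3CCN(C)CC3)nc(Nc3ccc(S(N)(=O)=O)cc3)n2)n[nH]1`: 1430 nM.

In a functional assay on K562 cells (Homo sapiens) for antiproliferative activity, read by CCK-8 assay, with a stated time of 72 h (on this read-out lower numbers stand for stronger inhibition and higher numbers for weaker inhibition), compound 1 holds the lowest of the three numbers; compound 2 sits within the scatter of it, as a 2.0-fold higher number from compound 1 to compound 2 (0.30 log units; within the scatter) shows, while compound 3 lies far off, with a 15-fold higher number from compound 1 to compound 3 (1.17 log units; beyond the scatter). Compound 4, `COc1ccc(Nc2nc(Nc3cc(C)[nH]n3)cc(N3CCN(C)CC3)n2)cc1`, is not yet measured; it differs from compound 1 in that (4-methoxyphenyl in place of 3-chlorophenyl on a nitrogen on an aromatic ring). For the measured compounds named here, two measured steps bear on this change: the small one, a 2.0-fold higher number from compound 1 to compound 2 (0.30 log units; within the scatter), and the large one, a 15-fold higher number from compound 1 to compound 3 (1.17 log units; beyond the scatter); between them, a 7.4-fold higher number from compound 2 to compound 3 (0.87 log units; beyond the scatter). A 4-methoxyphenyl is neither of the groups already seen, so a modest rise in the number is expected, a 3.1-fold higher number from compound 1 to compound 4 (0.49 log units; beyond the scatter). Compound 4 is estimated at 300 nM, between 120 nM and 800 nM.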

Compound 4, half-maximal inhibitory concentration: 271 nM
Compound 4: middle estimate off by 1.1-fold (0.04 log units), on the high side; low and high end bracket the measured number.
By their numbers in this assay, from the lowest: compounds 1, 2 and 4 (each within the scatter of the next, the first and the last beyond it); then compound 3.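

In this assay, the 4-methoxyphenyl stays within the scatter of the 4-chlorophenyl, a 1.4-fold higher number from compound 2 to compound 4 (0.15 log units; within the scatter), yet it recovers much of what the 4-sulfamoylphenyl lost, a 5.3-fold lower number from compound 3 to compound 4 (0.72 log units; beyond the scatter). Against the 3-chlorophenyl the change costs a modest amount, a 2.8-fold higher number from compound 1 to compound 4 (0.45 log units; beyond the scatter), so among these groups only the sulfamoyl brings a large loss. Nothing at hand explains these differences.

The compounds shown leave open how an amine or a carboxylic acid on this phenyl ring would fare. They also leave open how a 3-methoxyphenyl would compare.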